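Replacing the Boc-protected aminoethyl amide with a hydroxymethylcyclopropyl amide

This account rests on a few compounds, and the source may have more. Where it says the series, first, only, none or still open, it means among the compounds named here.

In a functional assay on BXPC-3 cells (Homo sapiens) for antiproliferative activity, read by MTT assay, with a stated time of 24 h (a higher number here means a weaker inhibitor, a lower number a stronger inhibitor), compound 1 `CCn1c(C(=O)NCCNC(=O)OC(C)(C)C)ccc1C(CC)(CC)c1ccc(OCS(=O)(=O)c2ccccc2)c(C)c1` gives > 50000 nM, which is a limit of the assay and not a number. Compound 1 therefore stands at the limit of > 50000 nM in this assay, at which 1 of the 3 values shown sits.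

Compound 4 `CCn1c(C(=O)NC2(CO)CC2)ccc1C(CC)(CC)c1ccc(OCS(=O)(=O)c2ccccc2)c(C)c1` has not yet been measured. It keeps the core of compound 1 but carries a different group on an amide-type nitrogen: 1-(hydroxymethyl)cyclopropyl in place of 2-((tert-butoxycarbonyl)amino)ethyl on an amide-type nitrogen. In short, 1-(hydroxymethyl)cyclopropyl stands in place of 2-((tert-butoxycarbonyl)amino)ethyl.

Two measured compounds bear on this change. Compound 2 `CCN(CC)CCNC(=O)c1ccc(C(CC)(CC)c2ccc(OCS(=O)(=O)c3ccccc3)c(C)c2)n1CC` gives 6270 nM, and compound 3 `CCn1c(C(=O)N[C@H](C)CO)ccc1C(CC)(CC)c1ccc(OCS(=O)(=O)c2ccccc2)c(C)c1` gives 10000 nM. The closer guide is compound 3, which carries 1-(hydroxymethyl)ethyl on the same amide-type nitrogen and shows an at least 5.0-fold lower number from compound 1 to compound 3 (0.69 log units; beyond the scatter). Compound 2 shows an at least 7.9-fold lower number from compound 1 to compound 2 (0.90 log units; beyond the scatter), so both changes away from the group in compound 1 gave steps beyond the scatter. Between these two compounds there is a 1.6-fold higher number from compound 2 to compound 3 (0.20 log units; within the scatter), which lies within the scatter.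

A step of similar size, towards a lower number in this assay, is therefore expected. The expected change is an at least 4.1-fold lower number from compound 1 to compound 4 (0.61 log units; beyond the scatter). For compound 4 the estimated value is 12000 nM, with an expected range from 4000 nM to 40000 nM.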

Compound 4, half-maximal inhibitory concentration: 45400 nM
Beside the measured number, compound 4's estimate is 3.8-fold (0.58 log units) below it, and the stated range ends below it.
By their numbers in this assay, from the lowest: compounds 2 and 3 (each within the scatter of the next); then compound 4. At a limit, above all of these: compound 1.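

In this assay, the change away from the group in compound 1 no longer gives a readable gain: the step is an at least 1.1-fold lower number from compound 1 to compound 4 (0.04 log units; that floor lies within the scatter), so compound 4 cannot be separated from compound 1, unlike compound 2 and compound 3, whose floors lay beyond the scatter. The result also shows that a hydroxymethyl group on this amide-type nitrogen does not settle the outcome, since closing the 1-(hydroxymethyl)ethyl group into 1-(hydroxymethyl)cyclopropyl gives a 4.5-fold higher number from compound 3 to compound 4 (0.66 log units; beyond the scatter), and 1-(hydroxymethyl)cyclopropyl in place of 2-(diethylamino)ethyl gives a 7.2-fold higher number from compound 2 to compound 4 (0.86 log units; beyond the scatter). Compound 1 itself stands at a limit of the assay and not a number: the limit of > 50000 nM in this assay, at which 1 of the 4 values shown sits.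

The compounds shown cannot tell whether the three-membered ring itself or the second carbon substituent on the carbon bound to the amide-type nitrogen accounts for the step from compound 3 to compound 4, and a 1-(hydroxymethyl)cyclobutyl group or a 2-hydroxy-2-methylpropyl chain on that nitrogen would bear on this. Also open, as far as these compounds go, is how the mirror-image form of the 1-(hydroxymethyl)ethyl group, a free primary amine or a carboxylic acid would read at this place.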